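The compounds below may be only part of what the source reports. "The series", "measured", "known", "first", "only" and "open" are said of these compounds alone.

Compound 2 `CC(C)(O)c1ccc(-c2cnc3c(n2)N(CC2CCOCC2)C(=O)CN3)cn1` stands highest of the two measured numbers in a functional assay on the whole organism (PC-3 cells) for inhibition, with Mus musculus as the target, in a xenograft, with a stated time of 4 h, at a dose of 100 mg/kg by the oral route (on this read-out lower numbers stand for less inhibition and higher numbers for more inhibition at the one dose given (going by the name of the read-out)), where compound 2 gives 93%. Compound 1 `COCCN1C(=O)CNc2ncc(-c3ccc(C(C)(C)O)nc3)nc21` gives 82% in this assay, so the measured step of a number 11 percentage points higher from compound 1 to compound 2 (beyond the scatter) lies beyond the scatter but is modest in size; it came from exchanging the group on a saturated chain carbon bound to an amide-type nitrogen in a ring. Compound 3 `CO[C@H]1CC[C@H](N2C(=O)CNc3ncc(-c4ccc(C(C)(C)O)nc4)nc32)CC1` alters the same amide-type nitrogen in a ring again: 4-methoxycyclohexyl in place of (oxan-4-yl)methyl on an amide-type nitrogen in a ring. For the measured compounds named here, the one step that bears on this change shows that reshaping the group carried by that nitrogen shifted the read-out only modestly while both values stayed high, and a percentage read-out has little room above the value of compound 2. The step of a number 5 percentage points lower from compound 2 to compound 3 (within the scatter) is therefore expected to stay within the scatter, leaning slightly downward. Compound 3 is estimated to give 88%, between 72% and 99%.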

Compound 3, a percentage reported as inhibition, in the whole organism at one dose (the size of the read-out at that dose, not a potency): 91%
Estimate against measurement, compound 3: 3 percentage points below; low and high end bracket the measured number.
By their numbers in this assay, from the lowest: compounds 1, 3 and 2 (each within the scatter of the next, the first and the last beyond it).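

In this assay, the exchange on the amide-type nitrogen in a ring gives a number 2 percentage points lower from compound 2 to compound 3 (within the scatter), so a six-membered ring of carbon only, carrying methoxy and two defined stereocentres, reads like the oxygen-containing ring of (oxan-4-yl)methyl. For the compounds shown here, the comparison with the open chain also becomes less clear-cut: a number 9 percentage points higher from compound 1 to compound 3 (within the scatter) stays within the scatter, whereas a number 11 percentage points higher from compound 1 to compound 2 (beyond the scatter) lies beyond it, so only one of the two ring-bearing groups is separated from 2-methoxyethyl. Nothing available gives a reason for these readings.

From the compounds shown here alone, how this position would respond to a group carrying an amine or a carboxylic acid remains open. Also open, going by these compounds, is how the other stereoisomer of 4-methoxycyclohexyl would read, and whether these compounds would separate at lower doses.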